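The source may hold more compounds than are shown below. What is called first, only, known or untested is meant among the compounds shown, and "the series" means these compounds.

Measured so far:
Compound 1 `C=C[C@@](C)(/C=C/c1ccc(O)cc1)CC/C=C(C)/C=N/N`: > 26000 nM
Compound 2 `C=C[C@@](C)(/C=C/c1ccc(O)cc1)CC/C=C(\C)C=O`: > 26000 nM

In a functional assay on Raji cells (Homo sapiens) for cytotoxicity, with a stated time of 72 h (a lower number here means that less compound is needed, a higher number that more compound is needed for the effect), compound 2 gives > 26000 nM, which is a limit and not a number. Compound 1 gives > 26000 nM, which is also a limit. All the evidence so far is therefore (the limit of > 26000 nM in this assay, at which 2 of the 2 values shown sit).

Compound 3 `C=C[C@@](C)(/C=C/c1ccc(O)cc1)CC/C=C(\C)CO` differs from compound 2 in one place: hydroxymethyl in place of formyl on a double-bonded chain carbon bound to a double-bonded chain carbon and a saturated chain carbon. It has hydroxymethyl in place of formyl on a double-bonded chain carbon bound to a double-bonded chain carbon and a saturated chain carbon. Among the compounds with values here, the only measured step at this place is a step that the two limits leave unreadable from compound 1 to compound 2, and it offers no size to carry over. No clear change is expected, and another limit is the likeliest result for compound 3. The expected step is a step that the limit leaves unreadable from compound 2 to compound 3. For compound 3 the estimated value is 30000 nM, with an expected range of 12000 nM to 60000 nM.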

Compound 3, half-maximal effective concentration: > 26000 nM
Compound 3 ended at the assay's limit; the forecaster's own chance of this, stated with the estimate: 80%; the middle value is on the limit's open side.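

Compound 3, like compound 1 and compound 2, gives only a limit and not a number in this assay, so no step among these three compounds can be read. Whether any group at this place changes the effect stays open, with all three compounds resting on one result: the limit of > 26000 nM in this assay, at which 3 of the 3 values shown sit.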